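Pyrazole replacement in an isopropoxy-benzamide series: expectation for compound 3

The source may hold more compounds than are shown below. What is called first, only, known or untested is meant among the compounds shown, and "the series" means these compounds.

Measured so far in an assay on cells for inhibition of MAP kinase-interacting serine/threonine-protein kinase 2 (Homo sapiens), read by mobility shift assay, with stated times of 10 min and 60 min, in the presence of a further agent that is not named here; on this read-out higher numbers stand for weaker inhibition and lower numbers for stronger inhibition:
Compound 1 `CC(C)Oc1cc(-c2cncc(-c3cnn(C4COC4)c3)c2)ccc1C(N)=O`: 89 nM
Compound 2 `CC(C)Oc1cc(-c2cncc(-c3cnn(C4CCOC4)c3)c2)ccc1C(N)=O`: 44 nM

Compound 1 gives the highest number of the two; its nearest neighbour is compound 2, reached by a 2.0-fold lower number from compound 1 to compound 2 (0.31 log units; beyond the scatter), a modest step beyond the scatter. That single step is the whole measured record for the series.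

The step under consideration leads from compound 1 to compound 3 `CC(C)Oc1cc(-c2cncc(-c3c[nH]nc3C3CC3)c2)ccc1C(N)=O`, still to be measured in this assay. The change is 3-cyclopropyl-1H-pyrazol-4-yl in place of 1-(oxetan-3-yl)-1H-pyrazol-4-yl on an aromatic carbon. It touches the same pyrazole-bearing position as the step from compound 1 to compound 2, but replaces the ring substituent pattern rather than exchanging one saturated ring for another, so the measured step does not bear on it directly; it shows only that alterations at this position have so far moved the number modestly.

Within the data shown here, with no comparable step on record, the expectation for compound 3 is a number close to that of compound 1, estimated at 70 nM, within 20 nM to 250 nM, i.e. an expected step of a 1.3-fold lower number from compound 1 to compound 3 (0.10 log units; within the scatter).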

Compound 3, half-maximal inhibitory concentration: 54 nM
Compound 3: the middle estimate sits 1.3-fold (0.11 log units) above what was measured, and the stated range covers the measured number.
By their numbers in this assay, from the lowest: compounds 2, 3 and 1 (each within the scatter of the next, the first and the last beyond it).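

In this assay, among these compounds, exchanging 1-(oxetan-3-yl)-1H-pyrazol-4-yl for 3-cyclopropyl-1H-pyrazol-4-yl gives a 1.6-fold lower number from compound 1 to compound 3 (0.22 log units; within the scatter), so this position on the six-membered aromatic ring with 1 nitrogen accepts more than an exchange of one oxygen-containing saturated ring for another on the aromatic nitrogen, the only kind of change the earlier compounds covered. The oxygen-containing ring can go, a carbon-only three-membered ring can sit on a pyrazole carbon, and the hydrogen-bond donor count can go from 0 to 1, all with a net step that stays within the scatter. No measurement at hand accounts for this outcome or assigns it to any one part of the change.

From the compounds shown here alone, the change alters several features at once, so the share of each stays open: the plain 1H-pyrazol-4-yl and 1-cyclopropyl-1H-pyrazol-4-yl would separate the effect of the free ring nitrogen-hydrogen from that of the cyclopropyl. Also open, going by these compounds, is how the number responds to other groups on the pyrazole carbon, such as an amine, a carboxylic acid or a longer chain like n-butyl.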